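Methylphenyl Sulfonyl Variant of the Shared Core

The source may hold more compounds than are shown below. What is called first, only, known or untested is meant among the compounds shown, and "the series" means these compounds.

Compound 1 `COc1ccc(-c2cc(=O)c3c(OC)cc(OC)cc3n2S(=O)(=O)c2ccc(C#N)cc2)cc1` — in an ADME assay on BJ cells (Homo sapiens) for antiproliferative activity, with a stated time of 72 h (on this read-out higher numbers stand for an effect only at larger amounts of compound and lower numbers for an effect already at smaller amounts), compound 1 gives > 17200 nM, which is a limit of the assay and not a number.
Compound 2 `COc1ccc(-c2cc(=O)c3c(OC)cc(OC)cc3n2S(=O)(=O)c2ccc(F)cc2)cc1` — in this assay compound 2 gives > 65500 nM, a limit.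
Compound 3 `COc1ccc(-c2cc(=O)c3c(OC)cc(OC)cc3n2S(=O)(=O)c2cc(Cl)cc(Cl)c2O)cc1` — in this assay compound 3 gives > 37900 nM, a limit.

Compound 3 thus stands at a limit, and the two further values shown are limits as well, so none of the three compounds can be ranked against another. Among the compounds with values here, the three measured steps, a step that the two limits leave unreadable from compound 1 to compound 2, a step that the two limits leave unreadable from compound 1 to compound 3 and a step that the two limits leave unreadable from compound 2 to compound 3, are all of a size the limits leave unreadable; they tell only that changing the group on the sulfonyl sulfur did not bring any compound into the measurable range.

Compound 4 `COc1ccc(-c2cc(=O)c3c(OC)cc(OC)cc3n2S(=O)(=O)c2ccc(C)cc2)cc1` differs from compound 3 by 4-methylphenyl in place of 3,5-dichloro-2-hydroxyphenyl on a sulfonyl sulfur. Within the data shown here, no measured step covers a 4-methylphenyl group on the sulfonyl sulfur, so the expectation rests on the three limits alone. The step expected from compound 3 to compound 4 in this assay is a step that the limit leaves unreadable from compound 3 to compound 4, most likely again a limit rather than a number. Compound 4 is estimated at 40000 nM, with a range from 15000 nM to 100000 nM.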

Compound 4, half-maximal effective concentration: > 44800 nM
Compound 4 ended at the assay's limit (the forecaster's own chance of this, stated with the estimate: 80%); at least 1.1-fold (0.04 log units) between middle value and limit.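

Compound 4 is a limit and so are compounds 1, 2 and 3, so none of the steps from those three compounds to compound 4 can be read. The compounds shown leave open whether any group on the sulfonyl sulfur would give a measurable value in this assay on the shared core.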